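The source may hold more compounds than are shown below. What is called first, only, known or untested is meant among the compounds shown, and "the series" means these compounds.

Measured compounds:
compound 1 `C[C@@H](CNc1ccc(Cl)cc1)[C@H]1CC[C@@H](c2ccnc3ccc(F)cc32)CC1`, which in an assay on tissue (HeLa cells) for inhibition of Indoleamine 2,3-dioxygenase 1 (Homo sapiens), with stated times of 2 h and 18 h (a lower number here means a stronger inhibitor, a higher number a weaker inhibitor), gives 7 nM
compound 2 `C[C@@H](NCc1ccc(Cl)cc1)[C@H]1CC[C@@H](c2ccnc3ccc(F)cc32)CC1`, which in this assay gives 745 nM

Going by the values given here, of these two numbers, compound 2 holds the higher one, so it is the weaker inhibitor of the pair; the single measured step, a 110-fold higher number from compound 1 to compound 2 (2.03 log units; beyond the scatter), shows that one change at this part of the molecule cost a great deal. Compound 3 `C[C@@H](NS(=O)(=O)c1ccc(Cl)cc1)[C@H]1CC[C@@H](c2ccnc3ccc(F)cc32)CC1` keeps the shared core and the amine nitrogen of compound 2 and alters only the group on that nitrogen: (4-chlorophenyl)sulfonyl in place of 4-chlorobenzyl on an amine nitrogen. Among the compounds with values here, no measured step covers this exchange; the step of a 110-fold higher number from compound 1 to compound 2 (2.03 log units; beyond the scatter) concerns a different change and offers no direction for this one. With no direct guide, a step of a 2.0-fold higher number from compound 2 to compound 3 (0.30 log units; within the scatter) is expected, so the estimate rests on compound 2 alone and is set wide. Compound 3 is therefore expected to give 1500 nM, in a range from 250 nM to 9000 nM.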

Compound 3, half-maximal inhibitory concentration: > 1000 nM
Compound 3 was reported as a limit (the forecaster's own chance of this, stated with the estimate: 15%); the middle value lies beyond the limit too.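

Compound 3 gives > 1000 nM in this assay, and this is a limit of the assay, not a number. The step is an at least 1.3-fold higher number from compound 2 to compound 3 (0.12 log units; that floor lies within the scatter), so putting (4-chlorophenyl)sulfonyl in place of 4-chlorobenzyl on the amine nitrogen, which brings in two hydrogen-bond acceptors by count, gives no stronger inhibitor, a point that the earlier pair could not address. How far the number truly rises cannot be read because the reading stops at a limit: the limit of > 1000 nM in this assay, at which 1 of the 3 values shown sits.

Still open, going by these compounds, is how a 4-chlorobenzoyl group, which puts a carbonyl on the same nitrogen, would compare with these two groups. Also open, on these data alone, is whether a sulfonyl linker would fare any better in the chain arrangement of compound 1, where the nitrogen carries the 4-chlorophenyl ring directly.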